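Compound 3: a new group on the sulfonyl sulfur

The source may hold more compounds than are shown below. What is called first, only, known or untested is meant among the compounds shown, and "the series" means these compounds.

Among the compounds with values here, in a physicochemical assay for solubility, in simulated intestinal fluid, with a stated time of 4 h (a higher number here means a more soluble compound, a lower number a less soluble compound), compound 1 `N#Cc1ccc(O[C@H]2CN(S(=O)(=O)c3ccc(Cl)cc3Cl)C[C@@]2(O)CO)cc1F` gives 19 ug/mL and compound 2 `N#Cc1ccc(O[C@H]2CN(S(=O)(=O)c3ccc(Cl)cc3Cl)C[C@]2(O)CO)cc1F` gives 88 ug/mL, the higher of the two numbers so far. The next structure is compound 3 `N#Cc1ccc(O[C@H]2CN(S(=O)(=O)c3ccc(Cl)cn3)C[C@]2(O)CO)cc1F`, which carries 5-chloropyridin-2-yl in place of 2,4-dichlorophenyl on a sulfonyl sulfur.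

Within the data shown here, only one measured step is available, a 4.6-fold higher number from compound 1 to compound 2 (0.67 log units; beyond the scatter). It bears on this change only as a yardstick of what this assay can show in this series. The evidence on that pair is the fact that compounds 1 and 2 differ only in the configuration as drawn, and 2,4-dichlorophenyl is present on both sides of it. Among the measured compounds shown here, no measurement yet tests a change of this group, so the size and direction below are a judgement with a wide margin. A modest upward move is expected, comparable in size to the step between the two configurations. The expected step is a 2.3-fold higher number from compound 2 to compound 3 (0.36 log units; beyond the scatter). For compound 3 the estimated value is 200 ug/mL, with an expected range of 70 ug/mL to 450 ug/mL.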

Compound 3, solubility: 130 ug/mL
Compound 3: the middle estimate sits 1.5-fold (0.19 log units) above what was measured; low and high end bracket the measured number.
By their numbers in this assay, from the lowest: compound 1; then compounds 2 and 3 (each within the scatter of the next).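

The sulfonyl sulfur now has its first measured change. In this assay, 5-chloropyridin-2-yl in place of 2,4-dichlorophenyl gives a 1.5-fold higher number from compound 2 to compound 3 (0.17 log units; within the scatter), so an exchange that brings in a ring nitrogen, counted as a hydrogen-bond acceptor, and leaves one chlorine on the ring cannot be told apart from repeat scatter, whereas the change in configuration alone gives a 4.6-fold higher number from compound 1 to compound 2 (0.67 log units; beyond the scatter) and lies beyond it. Among the compounds shown, the stereocentre at the saturated ring carbon is therefore the only place where a change exceeds the scatter, and nothing given here explains why the read-out separates one change and not the other.

Still open, on these data alone, is how the read-out moves when the sulfonyl sulfur carries something other than these two chlorinated aromatic rings, such as a morpholine ring, an aliphatic amine or a phenyl ring bearing a carboxylic acid. Also open, as far as these compounds go, is whether 5-chloropyridin-2-yl gives a similar number on the configuration of compound 1, so the two places cannot yet be judged as independent of each other.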